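A few compounds are considered here, and "the series" means these few. Any claim that something is new, unique, unknown or untested is made for them only; others in the source may bear on it.

Measured so far:
- Compound 1, `COc1ccc(C(=O)/C=C/c2ccc(OCc3cn(Cc4ccc(Br)cc4)nn3)cc2)cc1` — 59%
- Compound 2, `O=C(/C=C/c1ccc(OCc2cn(Cc3ccccc3)nn2)cc1)c1ccc([N+](=O)[O-])cc1` — "not active" (no number reported)
- Compound 3, `O=C(/C=C/c1ccc(OCc2cn(Cc3ccccc3Br)nn2)cc1)c1ccc([N+](=O)[O-])cc1` — 32%

In a functional assay on HepG2 cells (Homo sapiens) for inhibition, read by MTT assay, with a stated time of 48 h, tested at 10 uM (on this read-out lower numbers stand for less inhibition of growth and higher numbers for more inhibition of growth at the one concentration tested), compound 3 gives the lower of the two numbers reported; compound 1 stands higher by a gap beyond the scatter, and compound 2 is recorded only as inactive, without a number. Compound 4, `O=C(/C=C/c1ccc(OCc2cn(Cc3ccc(Br)cc3)nn2)cc1)c1ccc([N+](=O)[O-])cc1`, has not yet been measured in this assay. It differs from compound 3 in one place: 4-bromophenyl in place of 2-bromophenyl on a saturated chain carbon bound to an aromatic nitrogen. Among the measured compounds shown here, no step between measured compounds isolates this change, so the size of its effect is unknown. Compound 1, which also carries the 4-bromobenzyl group, gives the highest number in this assay, so a modest rise is expected, and the step from compound 3 to compound 4 is estimated at a number 10 percentage points higher from compound 3 to compound 4 (within the scatter). Compound 4 is therefore expected to reach about 42%, within a range from 22% to 62%.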

Compound 4, percent growth inhibition at one concentration: 21%
Compound 4: the middle estimate sits 21 percentage points above what was measured, outside the stated range (below it).
By their numbers in this assay, from the lowest: compound 4; then compound 3; then compound 1.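

In this assay, 4-bromophenyl in place of 2-bromophenyl on a saturated chain carbon bound to an aromatic nitrogen gives a number 11 percentage points lower from compound 3 to compound 4 (beyond the scatter), so with nitro held fixed the 2-bromobenzyl group gives the higher number. The 4-bromobenzyl group does not bring a high number by itself: nitro in place of methoxy on an aromatic carbon gives a number 38 percentage points lower from compound 1 to compound 4 (beyond the scatter). Nothing available here bears on the cause of either step.

From the compounds shown here alone, whether the order of the two bromobenzyl groups holds with methoxy in place of nitro remains open. So does the number that an amine or a carboxylic acid on that aromatic carbon would give.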